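A Second Chloro Group on the Shared Core

The source may report more compounds than this note shows. Statements on the series, on what has been measured and on what is new or still open speak of the compounds shown alone.

Measured so far:
compound 1 `ClCc1cccc(Cn2cnc3ncnc(Cl)c32)c1` gives 52500 nM in a functional assay on HOP-92 cells (Homo sapiens) for cytotoxicity, read by sulforhodamine B assay, with a stated time of 48 h; on this read-out lower numbers stand for higher toxicity in this test and higher numbers for lower toxicity in this test
compound 2 `ClCc1ccccc1Cn1cnc2ncnc(Cl)c21` gives 51300 nM in this assay
compound 3 `ClCc1cccc(Cn2cnc3nc(Cl)nc(Cl)c32)c1` gives 5240 nM in this assay

Compound 1 and compound 2 are built from the same atoms joined differently; how the two cores differ is not broken down here. Their numbers in this assay lie within the usual scatter of each other. Compound 3 differs from compound 1 by chloro in place of hydrogen on an aromatic carbon, and this change gave a 10-fold lower number from compound 1 to compound 3 (1.00 log units; beyond the scatter).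

Compound 4 `ClCc1ccccc1Cn1cnc2nc(Cl)nc(Cl)c21` has not yet been measured. It carries the same change on compound 2: chloro in place of hydrogen on an aromatic carbon, at a place described in the same words. For compound 4 a step of similar size is expected, a 10-fold lower number from compound 2 to compound 4 (1.00 log units; beyond the scatter). Among the measured compounds shown here, this expectation rests on a 10-fold lower number from compound 1 to compound 3 (1.00 log units; beyond the scatter), the one earlier instance of the change. The number expected for compound 4 is 5100 nM, with a likely range from 2000 nM to 13000 nM.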

Compound 4, concentration lethal to 50% of the cells: > 100000 nM
Compound 4: only a limit was reported; the forecaster's own chance of this, stated with the estimate: 5%; middle value at least 19-fold (1.29 log units) from the limit.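

The second chloro group did not carry over evenly from one core to the other in this assay: the same change on two cores in this assay, a 10-fold lower number (1.00 log units; beyond the scatter) from compound 1 to compound 3 and an at least 1.9-fold higher number (0.28 log units; that floor lies within the scatter) from compound 2 to compound 4, at least 19-fold (1.29 log units) apart, beyond the scatter of two such steps. On the core of compound 2, the change gave an at least 1.9-fold higher number from compound 2 to compound 4 (0.28 log units; that floor lies within the scatter), so the clear drop seen on the core of compound 1 did not repeat. Compound 4 gives > 100000 nM, which is a limit of the assay and not a number, and these results do not show why the two cores part ways.

As far as these compounds go, it remains open whether an amine or a methoxy group at this place, between two ring nitrogen atoms, would also act differently on the two cores. A third core could show which of the two results is more typical.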